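Swapping methoxy for chloro on a weakly cytotoxic ketone

The source may report more compounds than this note shows. Statements on the series, on what has been measured and on what is new or still open speak of the compounds shown alone.

- compound 1 `O=C(/C=C/c1ccc(Br)cc1)c1cccc(-c2cccc(F)c2)c1` gives 18200 nM
- compound 2 `COc1ccc(/C=C/C(=O)c2cccc(-c3cccc(F)c3)c2)cc1` gives 4510 nM

Both values come from a functional assay on SW480 cells (Homo sapiens) for cytotoxicity, read by sulforhodamine B assay, with a stated time of 48 h (a lower number here means a stronger inhibitor, a higher number a weaker inhibitor), and compound 2 holds the lower number of the two, which makes it the stronger inhibitor of this pair. The next compound to be measured is compound 3 `O=C(/C=C/c1ccc(Cl)cc1)c1cccc(-c2cccc(F)c2)c1` which differs from compound 2 in one place: chloro in place of methoxy on an aromatic carbon, para to a large group (chloro in place of methoxy on an aromatic carbon).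

Within the data shown here, only one measured step bears on this change (a 4.0-fold lower number from compound 1 to compound 2 (0.61 log units; beyond the scatter)) and it is modest but beyond the usual scatter. That step brought methoxy in place of bromo. Among the measured compounds shown here, the change to compound 3 runs the other way, since methoxy leaves, but chloro enters rather than bromo, and no chloro compound has a measured value yet. A higher number in this assay is therefore expected, of similar or somewhat smaller size than that one measured step. The expected change is a 2.7-fold higher number from compound 2 to compound 3 (0.43 log units; beyond the scatter) on this estimate. For compound 3 the estimated value is 12000 nM (expected range 5500 nM to 26000 nM).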

Compound 3, half-maximal inhibitory concentration: 16900 nM
For compound 3 the middle estimate is 1.4-fold (0.15 log units) below the measured one; the measured number falls inside the stated range.
By their numbers in this assay, from the lowest: compound 2; then compounds 3 and 1 (each within the scatter of the next).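

In this assay, going from 4-methoxyphenyl to 4-chlorophenyl gives a 3.7-fold higher number from compound 2 to compound 3 (0.57 log units; beyond the scatter), so removing methoxy from this position costs about as much as the earlier step gained when methoxy entered. The new compound also allows a direct comparison of two halogens at the same spot, and chloro and bromo cannot be told apart, with a 1.1-fold lower number from compound 1 to compound 3 (0.03 log units; within the scatter). Among these three compounds, then, the result depends on whether methoxy is present rather than on which of the two halogens is used, and compound 2 stands alone at the lower number, although no measurement here offers an explanation for that gap.

On these data alone, it remains open whether methoxy is special at this position or whether other groups, such as a hydroxy group, an ethoxy group, a dimethylamino group or a fluoro group, would match it or reach a lower number still. Also unsettled is whether the same gap between methoxy and chloro would persist if the fluorophenyl part of the shared core were changed.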